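From compound 3 to compound 4: hydroxy leaves, dimethylamino enters

This account rests on a few compounds, and the source may have more. Where it says the series, first, only, none or still open, it means among the compounds named here.

In a functional assay on HOP-62 cells (Homo sapiens) for inhibition, read by sulforhodamine B assay (a higher number here means a weaker inhibitor of growth, a lower number a stronger inhibitor of growth), compound 3 `Oc1ccc(-c2ccc(-c3ccc(-c4nc5c(O)cccc5[nH]4)cc3)cc2)cc1` gives 2410 nM and compound 2 `Oc1cccc2[nH]c(-c3ccc(-c4ccc(-c5ccc(F)cc5)cc4)cc3)nc12` stands higher at 8310 nM beyond the scatter. Compound 4 `CN(C)c1ccc(-c2ccc(-c3ccc(-c4nc5c(O)cccc5[nH]4)cc3)cc2)cc1` follows from compound 3 by dimethylamino in place of hydroxy on an aromatic carbon with dimethylamino in place of hydroxy on an aromatic carbon, para to a large group. Within the data shown here, the one measured step at this place is a 3.4-fold lower number from compound 2 to compound 3 (0.54 log units; beyond the scatter) for hydroxy in place of fluoro, modest but beyond the scatter. Compound 1 `Cc1ccc2[nH]c(-c3ccc(-c4ccc(-c5ccc(N(C)C)cc5)cc4)cc3)nc2c1` also carries 4-(dimethylamino)phenyl on a differently substituted core and gives 4230 nM within the scatter of compound 3. Among the measured compounds shown here, no step clearly beyond the scatter is therefore expected in this assay and the estimated step is a 1.5-fold higher number from compound 3 to compound 4 (0.16 log units; within the scatter) on this reading. For compound 4 the estimated value is 3500 nM with an expected range of 1500 nM to 8000 nM in repeated measurements.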

Compound 4, concentration for 50% growth inhibition: 8250 nM
Estimate against measurement, compound 4: 2.4-fold (0.37 log units) below; measured number above the stated range.
By their numbers in this assay, from the lowest: compounds 3, 1, 4 and 2 (each within the scatter of the next, the first and the last beyond it).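

In this assay, hydroxy at this place, para to a large group, now stands apart from two other groups: a 3.4-fold higher number from compound 3 to compound 4 (0.53 log units; beyond the scatter) joins the earlier step from fluoro to hydroxy in lying beyond the scatter. Dimethylamino and fluoro do not separate, with a 1.0-fold lower number from compound 2 to compound 4 (0.00 log units; within the scatter). With 4-(dimethylamino)phenyl kept, the change of core gives a 2.0-fold higher number from compound 1 to compound 4 (0.29 log units; within the scatter), so the two cores do not separate with this group. No measurement available here accounts for the hydroxy result. On these data alone, whether methoxy or an unsubstituted amino group at this place would track hydroxy or instead dimethylamino and fluoro remains open.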